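The compounds below may be only part of what the source reports. "The series", "measured", "known", "first", "only" and "open" are said of these compounds alone.

Compound 1 `O=C(NCc1cc(-c2ccc(C(F)(F)F)nc2)ncn1)[C@@H]1CCCN1S(=O)(=O)c1ccc(F)cc1`: 16 mL/min/kg
Compound 2 `C[C@H]1CC[C@@H](C(=O)NCc2cc(-c3ccc(C(F)(F)F)nc3)ncn2)N1S(=O)(=O)c1ccc(F)cc1`: 19 mL/min/kg
Compound 3 `C[C@@H]1CC[C@@H](C(=O)NCc2cc(-c3ccc(C(F)(F)F)nc3)ncn2)N1S(=O)(=O)c1ccc(F)cc1`: not yet measured

In an ADME assay on microsomes from liver (Homo sapiens) for pharmacokinetics (a lower number here means slower removal, a higher number faster removal of the compound), compound 2 stands at 19 mL/min/kg and compound 1 at 16 mL/min/kg, so the two lie within the scatter of each other and no third number is available for comparison.

Compound 3 keeps the atoms and bonds of compound 2: the two compounds have the same atoms and bonds and differ only in configuration as drawn: 1 of 2 stereo elements differ; a stereocentre at a saturated ring carbon is drawn S in compound 2 and R in compound 3 and the stereocentre at a saturated ring carbon is drawn S in compound 2 and R in compound 3.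

Among the compounds with values here, the only measured step is a 1.2-fold higher number from compound 1 to compound 2 (0.07 log units; within the scatter) for methyl in place of hydrogen on a saturated ring carbon, and it lies within the scatter. Within the data shown here, no measured pair differs in configuration alone, so this step is only a weak guide to the present change. No step beyond the scatter is expected in this assay and no direction can be given. The expected step is no change at the digits printed from compound 2 to compound 3 (within the scatter) and it stays within the scatter. The anchor is compound 2 at 19 mL/min/kg as the measured compound with the same atoms and bonds. For compound 3 the estimate is 19 mL/min/kg with an expected range of 10 mL/min/kg to 36 mL/min/kg.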

Compound 3, clearance: 19 mL/min/kg
Beside the measured number, compound 3's estimate shows no gap at the digits printed; the measured number falls inside the stated range.
By their numbers in this assay, from the lowest: compounds 1, 2 and 3 (each within the scatter of the next).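

In this assay, compounds 2 and 3 give the series its first comparison of configuration alone at a saturated ring carbon: the fact that compounds 2 and 3 differ only in the configuration as drawn. The step is no change at the digits printed from compound 2 to compound 3 (within the scatter), so this read-out does not separate the S and R forms drawn at this stereocentre. With a 1.2-fold higher number from compound 1 to compound 3 (0.07 log units; within the scatter) alongside a 1.2-fold higher number from compound 1 to compound 2 (0.07 log units; within the scatter), neither methyl compound stands apart from compound 1 beyond the scatter, and methyl in place of hydrogen on a saturated ring carbon reads the same way in both configurations.

From the compounds shown here alone, whether a larger or differently built group at this ring carbon, such as an ethyl, a hydroxymethyl or a gem-dimethyl pair, would also stay within the scatter remains open. Going by these compounds, the other stereocentre is drawn the same in compounds 2 and 3, so its configuration remains open too, as does whether the agreement between compound 2 and compound 3 would hold outside this assay.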